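The source may hold more compounds than are shown below. What is called first, only, known or untested is meant among the compounds shown, and "the series" means these compounds.

Compound 1 `COc1ccc(/C=C2\S/C(=N\c3ccccc3)N(Cc3ccco3)C2=O)cc1OC` was tested in a toxicity assay on CHO cells (Cricetulus griseus) for cytotoxicity, read by MTT assay, with a stated time of 48 h (a higher number here means a weaker inhibitor, a lower number a stronger inhibitor), and there compound 1 gives > 400000 nM, which is a limit of the assay rather than a number. Compound 2 `CC(C)Oc1ccc(/C=C2\S/C(=N\c3ccccc3)N(Cc3ccco3)C2=O)cc1` belongs to the same series, yet in this assay compound 2 gives "not determined" (no result reported). Going by the values given here, compound 1 thus stands at the limit of > 400000 nM in this assay, at which 1 of the 2 values shown sits, and no step between measured compounds can be drawn from these two entries. Compound 3 `COc1ccc(/C=C2\S/C(=N\c3ccccc3)N(Cc3ccco3)C2=O)cc1` has not yet been measured in this assay. It differs from compound 1 by hydrogen in place of methoxy on an aromatic carbon. With only a limit for compound 1 and no number for compound 2, the expected step in this assay is a number no higher from compound 1 to compound 3 (the limit leaves the size open), nothing beyond the usual scatter in either direction. Compound 3 is therefore estimated at 400000 nM, with a range from 100000 nM to 2000000 nM, and it seems likely that the assay will again report only a limit.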

Compound 3, half-maximal inhibitory concentration: > 400000 nM
Compound 3 ended at the assay's limit; the forecaster's own chance of this, stated with the estimate: 70%; the middle value sits exactly at the limit.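

No step can be read from compound 1 to compound 3, since in this assay each gives only a limit of the assay and not a number: the limit of > 400000 nM in this assay, at which 2 of the 3 values shown sit.

The compounds shown leave open whether hydrogen in place of methoxy changes the value at all.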